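This account rests on a few compounds, and the source may have more. Where it says the series, first, only, none or still open, it means among the compounds named here.

Values measured in a functional assay on HepG2 cells (Homo sapiens) for antiproliferative activity, read by MTT assay; on this read-out higher numbers stand for weaker inhibition and lower numbers for stronger inhibition:

- compound 1 `Cc1c(-n2cc(COc3ccc(/C=C/C(=O)c4cc5c(cc4O)OC(C)(C)CC5)cc3)nn2)cccc1[N+](=O)[O-]` gives 109000 nM
- compound 2 `CCc1ccccc1-n1cc(COc2ccc(/C=C/C(=O)c3cc4c(cc3O)OC(C)(C)CC4)cc2)nn1` gives 115000 nM
- compound 3 `CC1(C)CCc2c(ccc(C(=O)/C=C/c3ccc(OCc4cn(-c5ccc(Cl)cc5)nn4)cc3)c2O)O1` gives 102000 nM

Compound 3, at 102000 nM, lies within the scatter of both compound 1 and compound 2, so the three numbers do not separate. Compound 4 `Cc1c(-n2cc(COc3ccc(/C=C/C(=O)c4ccc5c(c4O)CCC(C)(C)O5)cc3)nn2)cccc1[N+](=O)[O-]` keeps the core of compound 3 and carries 2-methyl-3-nitrophenyl in place of 4-chlorophenyl on an aromatic nitrogen. Going by the values given here, the one measured exchange at this place is a 1.1-fold higher number from compound 1 to compound 2 (0.02 log units; within the scatter), which stays within the scatter. Compound 1 has the entering group on a different core and gives 109000 nM. No step beyond the scatter is therefore expected in this assay. The expected step is a 1.0-fold higher number from compound 3 to compound 4 (0.01 log units; within the scatter). For compound 4 the estimated value is 105000 nM, with an expected range from 65000 nM to 170000 nM.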

Compound 4, half-maximal inhibitory concentration: 115000 nM
Compound 4: middle estimate off by 1.1-fold (0.04 log units), on the low side, within the range that was stated.
By their numbers in this assay, from the lowest: compounds 3, 1, 2 and 4 (each within the scatter of the next).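

On the core of compound 3, the exchange of 4-chlorophenyl for the larger 2-methyl-3-nitrophenyl, which adds two hydrogen-bond acceptors, gives a 1.1-fold higher number from compound 3 to compound 4 (0.05 log units; within the scatter) in this assay and so does not separate the two compounds. The earlier step at this place, a 1.1-fold higher number from compound 1 to compound 2 (0.02 log units; within the scatter), came from a different core, so the aromatic nitrogen has now tolerated an exchange on both cores without a step beyond the scatter. Nothing available explains this flat response. Still open, from the compounds shown here alone, is whether a substituted phenyl carrying an amine or a carboxylic acid, or a longer alkyl chain in place of the phenyl ring, would move the number beyond the scatter.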